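The source may hold more compounds than are shown below. What is called first, only, known or untested is meant among the compounds shown, and "the series" means these compounds.

Notes on the series. The shared core of compound 1 `COc1ccc(Cl)cc1NS(=O)(=O)c1ccc(OC)c(N2CCNCC2)c1` carries a sulfonamide nitrogen whose aryl group is varied across the set. For the measured compounds named here, in an assay on isolated protein for binding affinity to 5-hydroxytryptamine receptor 6 (Homo sapiens) (on this read-out higher numbers stand for weaker inhibition and lower numbers for stronger inhibition), compound 1 gives 1.26 nM, the lowest of the three numbers measured so far. Compound 2 `COc1ccc(S(=O)(=O)Nc2ccc(C)cc2Br)cc1N1CCNCC1` gives 7.94 nM in this assay, and compound 3 `COc1ccc(S(=O)(=O)Nc2cc(Cl)c(Cl)cc2Cl)cc1N1CCNCC1` gives 5.01 nM. Both changes away from compound 1 raised the number: a 6.3-fold higher number from compound 1 to compound 2 (0.80 log units; beyond the scatter) and a 4.0-fold higher number from compound 1 to compound 3 (0.60 log units; beyond the scatter). Between the two halogenated aryls themselves the gap is small, a 1.6-fold lower number from compound 2 to compound 3 (0.20 log units; within the scatter).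

Compound 4 `COc1ccc(S(=O)(=O)Nc2cc(F)cc(F)c2Cl)cc1N1CCNCC1` is not yet measured. Relative to compound 1 the change is 2-chloro-3,5-difluorophenyl in place of 5-chloro-2-methoxyphenyl on a sulfonamide nitrogen. Going by the values given here, the steps that bear on this are those from compound 1 to compound 2 and from compound 1 to compound 3, since each likewise exchanges the 5-chloro-2-methoxyphenyl for an aryl that carries halogen only and loses the one hydrogen-bond acceptor; both were modest rises beyond the scatter. Among the compounds with values here, the closest precedent is compound 3, whose 2,4,5-trichlorophenyl is also an all-halogen aryl. Compound 4 is therefore expected to sit higher than compound 1 by roughly the size of a 4.0-fold higher number from compound 1 to compound 3 (0.60 log units; beyond the scatter), an expected step of a 4.0-fold higher number from compound 1 to compound 4 (0.60 log units; beyond the scatter). The estimate for compound 4 in this assay is 5 nM, with a range from 1.6 nM to 16 nM.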

Compound 4, inhibition constant: 31.6 nM
Compound 4: the middle estimate sits 6.3-fold (0.80 log units) below what was measured; the measured number lies above the stated range.
By their numbers in this assay, from the lowest: compound 1; then compounds 3 and 2 (each within the scatter of the next); then compound 4.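

In this assay, for the compounds shown here, the aryl group on the sulfonamide nitrogen can shift the number much further than the earlier compounds suggested (a 25-fold higher number from compound 1 to compound 4 (1.40 log units; beyond the scatter)), a large step where those before it were modest. Aryl groups carrying only halogen also do not share one level: 2-chloro-3,5-difluorophenyl stands clearly apart from both earlier halogenated aryls (a 6.3-fold higher number from compound 3 to compound 4 (0.80 log units; beyond the scatter); a 4.0-fold higher number from compound 2 to compound 4 (0.60 log units; beyond the scatter)), although the two earlier ones lie within the scatter of each other, so the absence of a methoxy group does not alone set the number at this position. Nothing available accounts for why this particular halogen arrangement gives the highest number of the set.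

Because every aryl group here differs from the others in more than one substituent, the separate contributions of the methoxy group, the fluorines and the chlorines remain unresolved. Also open, going by these compounds, is how the 5-chloro-2-methoxyphenyl series would read with a nitrile, a dimethylamino group or a carboxylic acid in place of the methoxy group.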